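The source may report more compounds than this note shows. Statements on the series, on what has been measured and on what is new or still open speak of the compounds shown alone.

In an in vitro functional assay on cells for agonist activity at Bombesin receptor subtype-3 (Mus musculus), read by luminescence and calcium flux (on this read-out lower numbers stand for an effect already at smaller amounts and higher numbers for an effect only at larger amounts of compound), compound 2 `CC(C)(C)Cc1cnc(CCc2ccc(-c3ccccc3C(=O)O)cc2)[nH]1` gives 6.3 nM. Compound 1 `O=C(O)c1ccccc1-c1ccc(CCc2ncc(Cc3ccccc3F)[nH]2)cc1` gives 9.5 nM in this assay, and the step of a 1.5-fold lower number from compound 1 to compound 2 (0.18 log units; within the scatter) lies within the scatter, so the two numbers sit together. Compound 3 `O=C(O)c1ccccc1-c1ccc(CCc2ncc(CC3CCCCCC3)[nH]2)cc1` differs from compound 2 by cycloheptyl in place of tert-butyl on a saturated chain carbon bound to an aromatic carbon. Among the compounds with values here, the one measured step at this place, a 1.5-fold lower number from compound 1 to compound 2 (0.18 log units; within the scatter), exchanged one group for another without moving the number beyond the scatter, so no movement beyond the scatter is expected here either. Compound 3 is expected to show a step of a 1.3-fold higher number from compound 2 to compound 3 (0.10 log units; within the scatter). Compound 3 is therefore estimated at 8 nM in this assay, between 2.5 nM and 30 nM.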

Compound 3, half-maximal effective concentration: 5.7 nM
The estimate for compound 3 lay 1.4-fold (0.15 log units) above the measured number; the range from low to high includes it.
By their numbers in this assay, from the lowest: compounds 3, 2 and 1 (each within the scatter of the next).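

The move to a ring now shows that this place, on a saturated chain carbon bound to an aromatic carbon, accepts a larger saturated group of 7 heavy atoms in place of the 4 of tert-butyl without a real shift in this assay: the change gives a 1.1-fold lower number from compound 2 to compound 3 (0.04 log units; within the scatter), and the change from 2-fluorophenyl gives a 1.7-fold lower number from compound 1 to compound 3 (0.22 log units; within the scatter). All three groups therefore sit together, and no evidence here accounts for this. Going by these compounds, whether a group carrying an amine or a hydroxyl, or a much longer chain, would stay within the scatter remains open.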